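Swapping Fluoro for Chloro in a Calpain Inhibitor

The compounds below may be only part of what the source reports. "The series", "measured", "known", "first", "only" and "open" are said of these compounds alone.

Of the compounds shown here, two have been measured in an assay on isolated protein for inhibition of Calpain-1 catalytic subunit (Sus scrofa); on this read-out lower numbers stand for stronger inhibition and higher numbers for weaker inhibition. Compound 1, with the structure `O=C(O)/C(S)=C/c1c[nH]c2cc(Br)ccc12`, gives 90 nM in this assay. Compound 2, with the structure `O=C(O)/C(S)=C/c1c[nH]c2cccc(F)c12`, gives 300 nM in this assay. Of these two numbers, compound 2 has the higher one; the nearest is compound 1, whose number is lower by an amount beyond the usual scatter. Compound 3, with the structure `O=C(O)/C(S)=C/c1c[nH]c2cccc(Cl)c12`, has not yet been measured. It differs from compound 2 in one place: chloro in place of fluoro on an aromatic carbon. Going by the values given here, no measured pair shows a change of this kind, so the expectation rests on the structural change alone. For compound 3 the expected step is a 1.5-fold lower number from compound 2 to compound 3 (0.18 log units; within the scatter), a small move toward a lower number, not clearly beyond the scatter. Compound 3 is therefore estimated at 200 nM, with a range from 70 nM to 600 nM.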

Compound 3, half-maximal inhibitory concentration: 140 nM
For compound 3 the middle estimate is 1.4-fold (0.15 log units) above the measured one, and the stated range covers the measured number.
By their numbers in this assay, from the lowest: compounds 1 and 3 (each within the scatter of the next); then compound 2.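

Going by these compounds alone, this pair differs in one atom only, so it gives the first direct reading of a single change on the shared core in this assay. Chloro in place of fluoro, on an aromatic carbon ortho to a fused ring, gives a 2.1-fold lower number from compound 2 to compound 3 (0.33 log units; beyond the scatter), which shows that swapping one halogen for another at this position can shift the number by a modest but readable amount. Nothing available here bears on what lies behind this step.

Still open, from the compounds shown here alone, is how a methyl group, a methoxy group or a plain hydrogen on this same carbon would compare with chloro and fluoro. A single pair also leaves open whether the same swap would give a step of similar size on other carbons of this ring.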